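A few compounds are considered here, and "the series" means these few. Any claim that something is new, unique, unknown or untested is made for them only; others in the source may bear on it.

Compound 1 `O=[N+]([O-])c1ccc(NC(=S)NCc2cccc(Cl)c2)cc1` is a thiourea that, in a functional assay on U-373MG ATCC cells (Homo sapiens) for inhibition, read by MTT assay, with a stated time of 72 h (on this read-out higher numbers stand for weaker inhibition and lower numbers for stronger inhibition), gives 27000 nM. Compound 2 `COc1ccc(Cl)cc1CNC(=S)Nc1ccc([N+](=O)[O-])cc1` carries one added group, a (methoxy in place of hydrogen on an aromatic carbon), and in this assay compound 2 gives 22000 nM. The step of a 1.2-fold lower number from compound 1 to compound 2 (0.09 log units; within the scatter) is therefore small. Compound 3 `O=[N+]([O-])c1cccc(NC(=S)NCc2cccc(Cl)c2)c1` is built from the same atoms as compound 1, joined differently; the difference between the two cores is not broken down here. In this assay, for the measured compounds named here, compound 3 gives 32000 nM, and its value and that of compound 1 are within the scatter of each other, as are all three values so far.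

Compound 4 `COc1ccc(Cl)cc1CNC(=S)Nc1cccc([N+](=O)[O-])c1` has not yet been measured in this assay. It stands to compound 3 as compound 2 stands to compound 1: the change is methoxy in place of hydrogen on an aromatic carbon, the same change at the same kind of place. The expected step of a 1.2-fold lower number from compound 3 to compound 4 (0.07 log units; within the scatter) is estimated to be as small as the earlier one, because a 1.2-fold lower number from compound 1 to compound 2 (0.09 log units; within the scatter) showed almost no movement. Compound 4 is expected to give about 27000 nM, most likely between 15000 nM and 50000 nM.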

Compound 4, half-maximal inhibitory concentration: 32000 nM
Beside the measured number, compound 4's estimate is 1.2-fold (0.07 log units) below it, and the stated range covers the measured number.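

In this assay, methoxy in place of hydrogen on an aromatic carbon again leaves the number where it stood, the new step being no change at the digits printed from compound 3 to compound 4 (within the scatter). Set beside the earlier step, the change reads the same on the two cores: the same change on two cores in this assay, a 1.2-fold lower number (0.09 log units; within the scatter) from compound 1 to compound 2 and no change at the digits printed (within the scatter) from compound 3 to compound 4, 1.2-fold (0.09 log units) apart, within the scatter of two such steps. This shows that the change carried from one core to the other as a step within the scatter on both, but it does not show that methoxy would do the same on any other core in the series, and two steps this small say nothing about why the numbers stay put.

From the compounds shown here alone, all four compounds keep the chloro group and the nitro group, and methoxy appears at only one place, para to a chloro group, so the effect of moving it elsewhere remains open. Going by these compounds, whether an amine, a carboxylic acid or a longer chain at that place would move the number beyond the scatter also remains open.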